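A few compounds are considered here, and "the series" means these few. Any claim that something is new, unique, unknown or untested is made for them only; others in the source may bear on it.

Measured so far in a functional assay on A549 cells (Homo sapiens) for antiproliferative activity, read by MTT assay, with a stated time of 72 h; on this read-out higher numbers stand for weaker inhibition and lower numbers for stronger inhibition:

Compound 1 `S=C(Sc1ccccc1)N1CCOCC1`: 2520 nM
Compound 2 `CCCCN(CCCC)C(=S)Sc1ccccc1`: 9760 nM
Compound 3 `COc1ccc(SC(=S)N2CCN(C(=O)OC(C)(C)C)CC2)cc1`: 712 nM

Compound 3 has the lowest of these three numbers, so it is the strongest inhibitor of the set. Both compound 1 and compound 2 lie above it by more than the usual scatter of repeated measurements, and compound 2 lies furthest away.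

The next compound, compound 4 `Cc1ccccc1SC(=S)N1CCN(C(=O)OC(C)(C)C)CC1`, has not yet been measured. It keeps the rest of compound 3 but carries 2-methylphenyl in place of 4-methoxyphenyl on a sulfur. Going by the values given here, no measured pair shows what a swap at this place does, so the expectation rests on compound 3 at 712 nM, the only measured compound sharing that remainder. No change beyond the scatter is expected, with only a slight lean towards weaker inhibition. The estimated step is a 1.4-fold higher number from compound 3 to compound 4 (0.15 log units; within the scatter). In this assay, the expected value for compound 4 is 1000 nM, within an estimated range from 350 nM to 3000 nM.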

Compound 4, half-maximal inhibitory concentration: 2270 nM
Estimate against measurement, compound 4: 2.3-fold (0.36 log units) below, within the range that was stated.
By their numbers in this assay, from the lowest: compound 3; then compounds 4 and 1 (each within the scatter of the next); then compound 2.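

In this assay, this pair gives the first direct view of the group on this sulfur: with the rest of the molecule unchanged, 2-methylphenyl in place of 4-methoxyphenyl gives a 3.2-fold higher number from compound 3 to compound 4 (0.50 log units; beyond the scatter). The group here can therefore shift the number on its own, even though both groups contain one six-membered aromatic ring of carbon only and the swap takes away one hydrogen-bond acceptor. Nothing available explains the rise, and this one pair cannot separate the loss of the methoxy group from the gain of the methyl group or from where each sits on the ring.

With the rest kept, 4-methylphenyl or 2-methoxyphenyl on this sulfur would help tell those possibilities apart. As far as these compounds go, how a chlorophenyl or pyridine ring would behave here remains open.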